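Aryl Ether Gives Way to Aryl Thioether on a Diamino Core

This account rests on a few compounds, and the source may have more. Where it says the series, first, only, none or still open, it means among the compounds named here.

Compound 1 `Nc1cc(N)c2nc(-c3ccccc3)c(Oc3ccc(Cl)c(Cl)c3)nc2c1` carries a 3,4-dichlorophenoxy group on its core. In a functional assay on SF-295 cells (Homo sapiens) for inhibition, read by sulforhodamine B assay, with a stated time of 48 h (on this read-out higher numbers stand for weaker inhibition of growth and lower numbers for stronger inhibition of growth), compound 1 gives 30900 nM, the highest of the two plain numbers in hand. Compound 3 `COc1cc(CNc2nc3cc(N)cc(N)c3nc2-c2ccccc2)cc(OC)c1OC` gives 5620 nM, a lower number separated from compound 1 by a gap beyond the usual scatter. Compound 2 `CCOC(=O)[C@H](CCC(=O)O)NC(=O)c1ccc(Sc2nc3cc(N)cc(N)c3nc2-c2ccccc2)cc1` reaches only a limit, < 100000 nM, so it cannot be ranked against the others. Compound 4 `COc1ccc(Sc2nc3cc(N)cc(N)c3nc2-c2ccccc2)cc1` has not yet been measured; it differs from compound 1 by (4-methoxyphenyl)sulfanyl in place of 3,4-dichlorophenoxy on an aromatic carbon. Among the compounds with values here, no measured pair shows a step of this kind, so the step of a 1.5-fold lower number from compound 1 to compound 4 (0.19 log units; within the scatter) is expected to be small, toward a lower number, and possibly within the scatter. Compound 4 is therefore estimated at 20000 nM, with a range from 5000 nM to 80000 nM.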

Compound 4, concentration for total growth inhibition: < 100000 nM
Compound 4 gave a limit, no number (the forecaster's own chance of this, stated with the estimate: 20%); the middle value is on the limit's open side.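

Compound 4 gives only a limit and not a number, so no step from compound 1 to compound 4 can be read: the limit of < 100000 nM in this assay, at which 2 of the 4 values shown sit.

The compounds shown leave open whether (4-methoxyphenyl)sulfanyl in place of 3,4-dichlorophenoxy changes growth inhibition at all, and in which direction.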